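One Added Hydroxy Group on Compound 1

The source may hold more compounds than are shown below. What is called first, only, known or untested is meant among the compounds shown, and "the series" means these compounds.

Within the data shown here, in a physicochemical assay for lipophilicity (on this read-out lower numbers stand for lower lipophilicity and higher numbers for higher lipophilicity), compound 1 (`Cc1cccc2c1OP(=O)(OCC1CCC(n3cnc4c(O)ncnc43)O1)OC2`) gives 0.14 and so holds the lower of the two numbers measured so far. Compound 2 (`COc1ccc2c(c1)COP(=O)(OCC1CCC(n3cnc4c(N)ncnc43)O1)O2`) gives 0.64 in this assay and sits higher, by a gap beyond the usual scatter of repeated measurements. These two compounds differ in more than one place, so their gap cannot be pinned on any single change.

Compound 3 (`Cc1cccc2c1OP(=O)(OCC1CC(O)C(n3cnc4c(O)ncnc43)O1)OC2`) has not been measured yet. It keeps the core of compound 1 and changes in one place, with hydroxy in place of hydrogen on a saturated ring carbon. Among the measured compounds shown here, no measured pair shows this change on its own, so the expectation rests on the structural change alone, and it carries real uncertainty.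

A clear move toward lower numbers in this assay is expected, larger than the scatter. The estimated size is a number 0.84 log units lower from compound 1 to compound 3 (beyond the scatter) on this read-out. The expected value for compound 3 is -0.7 with a range from -1.2 to -0.2 as the estimate.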

Compound 3, partition coefficient: 0.078
Compound 3: middle estimate off by 0.78 log units, on the low side, outside the stated range (above it).
By their numbers in this assay, from the lowest: compounds 3 and 1 (each within the scatter of the next); then compound 2.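

Hydroxy in place of hydrogen on this saturated ring carbon, next to the ring atom that bears a large group, gives the first step in this set that can be traced to one place: in this assay it reads a number 0.06 log units lower from compound 1 to compound 3 (within the scatter) and so leaves compound 3 and compound 1 indistinguishable on this read-out. Among these compounds, the gap between compound 1 and compound 2 could not show this, as those two compounds differ in more than one place, whereas here the hydroxy, with its 1 hydrogen-bond donor and 1 hydrogen-bond acceptor, is the only change and the number does not separate from that of the parent. Nothing available here offers an explanation for this result.

This single pair speaks only for hydroxy at this one ring carbon on the core of compound 1, so it cannot say whether the same swap on the core of compound 2 would also stay within the scatter. On these data alone, whether an amine, a carboxylic acid or a longer chain on this same ring carbon would leave the number just as close to that of compound 1 remains open.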